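Aryl exchange at the shared core: compound 4

This account rests on a few compounds, and the source may have more. Where it says the series, first, only, none or still open, it means among the compounds named here.

For the measured compounds named here, compound 3 `Cc1csc(-c2nc(N)c3cc(CN4[C@H](C)CCC[C@@H]4C)sc3n2)n1` holds the second highest of the three numbers known in an assay on CHO-K1 cells for antagonist activity at adenosine receptor A1 (Homo sapiens), read by a beta-galactosidase reporter, with stated times of 15 min and 6 h; on this read-out higher numbers stand for weaker inhibition and lower numbers for stronger inhibition: compound 3 gives 300 nM. Its nearest neighbour is compound 1 `CCc1ccc(-c2nc(N)c3cc(CN4[C@H](C)CCC[C@@H]4C)sc3n2)o1`, which in this assay gives 190 nM; the step of a 1.6-fold higher number from compound 1 to compound 3 (0.20 log units; within the scatter) lies within the scatter. Compound 2 `C[C@@H]1CCC[C@H](C)N1Cc1cc2c(N)nc(-c3ccc(C(F)F)o3)nc2s1` gives 730 nM, and the step of a 2.4-fold lower number from compound 2 to compound 3 (0.39 log units; beyond the scatter) lies beyond the scatter. The third step at the same aromatic carbon, a 3.8-fold higher number from compound 1 to compound 2 (0.58 log units; beyond the scatter), is likewise modest. Taken together, exchanging the group on this carbon has so far moved the number by a small to modest amount.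

Compound 4 `C[C@@H]1CCC[C@H](C)N1Cc1cc2c(N)nc(-c3cccc(C#N)c3)nc2s1` differs from compound 3 by 3-cyanophenyl in place of 4-methyl-1,3-thiazol-2-yl on an aromatic carbon. Going by the values given here, no measured step exchanges a five-membered heteroaryl for a six-membered carbocycle at this carbon, so the direction is not set by the data; the measured steps at this carbon were small to modest, so a step of similar size is expected. The step of a 1.2-fold higher number from compound 3 to compound 4 (0.07 log units; within the scatter) is therefore estimated as modest with uncertain direction. Compound 4 is expected to give 350 nM in this assay, within 100 nM to 1200 nM.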

Compound 4, inhibition constant: 460 nM
The estimate for compound 4 lay 1.3-fold (0.12 log units) below the measured number; the range from low to high includes it.
By their numbers in this assay, from the lowest: compounds 1, 3, 4 and 2 (each within the scatter of the next, the first and the last beyond it).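

The 3-cyanophenyl group brings the first six-membered aromatic ring of carbon only to this carbon, and in this assay the exchange gives a 1.5-fold higher number from compound 3 to compound 4 (0.19 log units; within the scatter) and a 1.6-fold lower number from compound 2 to compound 4 (0.20 log units; within the scatter) with two of the five-membered groups. Against the remaining group the exchange gives a 2.4-fold higher number from compound 1 to compound 4 (0.38 log units; beyond the scatter) and this modest step leaves compound 4 inside the span already set by compound 1 and compound 2, so the change of ring size has opened no larger gap at this carbon. No supporting data bear on why these numbers fall as they do.

On these data alone, what the nitrile adds beyond the six-membered ring itself stays open, as does the reading with a methoxy group or a primary amide in its place. Also open, as far as these compounds go, is whether an amine or a carboxylic acid on this ring would move the number further than these modest steps.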